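Dopamine transporter series: chloro to trifluoromethylsulfanyl step

The source may hold more compounds than are shown below. What is called first, only, known or untested is meant among the compounds shown, and "the series" means these compounds.

Measured compounds:
compound 1 `O[C@](Cc1ccccc1)(c1ccccc1)[C@@H]1CNCCO1`: 5.5%
compound 2 `O[C@](Cc1ccccc1Cl)(c1ccccc1)[C@@H]1CNCCO1`: 20.8%

In an assay on isolated protein for displacement of a labelled ligand from sodium-dependent dopamine transporter (Homo sapiens), tested at 1000 nM (on this read-out higher numbers stand for more inhibition at the one concentration tested (going by the name of the read-out) and lower numbers for less inhibition), compound 1 gives 5.5% and compound 2 gives 20.8%. Among the measured compounds shown here, compound 2 stands highest of the two numbers; the step of a number 15.3 percentage points higher from compound 1 to compound 2 (beyond the scatter) lies beyond the scatter and is the only measured step so far. Compound 3 `O[C@](Cc1ccccc1SC(F)(F)F)(c1ccccc1)[C@@H]1CNCCO1` differs from compound 2 by (trifluoromethyl)sulfanyl in place of chloro on an aromatic carbon, sitting on an aromatic carbon of the six-membered aromatic ring of carbon only, ortho to a large group. For the measured compounds named here, only the step of a number 15.3 percentage points higher from compound 1 to compound 2 (beyond the scatter) bears on this change, and it concerns a different group entering in place of hydrogen; it gives a direction but no firm size. A further modest rise in this assay is expected for compound 3, though a step within the scatter cannot be ruled out. Compound 3 is estimated at 32%, with a range from 12% to 55%, which means an expected step of a number 11.2 percentage points higher from compound 2 to compound 3 (beyond the scatter).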

Compound 3, a percentage reported as inhibition, at one concentration (the size of the read-out at that concentration, not a potency): 6.2%
Compound 3: the middle estimate sits 25.8 percentage points above what was measured; the whole stated range lies above it.
By their numbers in this assay, from the lowest: compounds 1 and 3 (each within the scatter of the next); then compound 2.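

In this assay, the place ortho to a large group proves sensitive to which group sits there: (trifluoromethyl)sulfanyl in place of chloro gives a number 14.6 percentage points lower from compound 2 to compound 3 (beyond the scatter) and so does not extend the rise seen with chloro. Measured against hydrogen, the same group gives a number 0.7 percentage points higher from compound 1 to compound 3 (within the scatter) and leaves no readable gain, so among these three compounds the rise belongs to chloro alone. Nothing available accounts for the different outcomes of these two groups.

Open, going by these compounds, is whether fluoro, bromo or methyl at this place would track chloro or (trifluoromethyl)sulfanyl. Also open, on these data alone, is what an amine or a carboxylic acid would do there, since both groups tested so far carry no charge and no hydrogen-bond donor.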